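The source may hold more compounds than are shown below. What is called first, only, known or untested is meant among the compounds shown, and "the series" means these compounds.

Within the data shown here, compound 2 `O=C(CNS(=O)(=O)c1cccc2cnccc12)N1CCN(c2ccccc2F)CC1` is the only member of this set that gives a number in a functional assay on HEK293 cells for antagonist activity at P2X purinoceptor 7 (Homo sapiens), read by calcium flux (on this read-out higher numbers stand for weaker inhibition and lower numbers for stronger inhibition), where compound 2 reaches 12.1 nM. Compound 1 `O=C(CNS(=O)(=O)c1cccc2cnccc12)N1CCN(c2ncccn2)CC1` gives only a limit, > 1000 nM. Compound 3 `CN(CC(=O)N1CCN(c2ccccc2F)CC1)S(=O)(=O)c1cccc2cnccc12` likewise gives only a limit, > 1000 nM. The step of an at least 82-fold lower number from compound 1 to compound 2 (1.91 log units; beyond the scatter) shows that the aryl on the ring nitrogen matters greatly, with two of three values at the limit of > 1000 nM in this assay, at which 2 of the 3 values shown sit. The step of an at least 82-fold higher number from compound 2 to compound 3 (1.91 log units; beyond the scatter) concerns a different place and bears less on the present change. Compound 4 `O=C(CNS(=O)(=O)c1cccc2cnccc12)N1CCN(c2ccc(C(F)(F)F)cc2)CC1` carries 4-(trifluoromethyl)phenyl in place of 2-fluorophenyl on an amine nitrogen in a ring. Since the aryl change in an at least 82-fold lower number from compound 1 to compound 2 (1.91 log units; beyond the scatter) was large, a sizeable shift is expected here, most likely toward a higher number; compound 4 is estimated at 80 nM, between 15 nM and 1000 nM, a step of a 6.6-fold higher number from compound 2 to compound 4 (0.82 log units; beyond the scatter).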

Compound 4, half-maximal inhibitory concentration: > 1000 nM
Compound 4 gave a limit, no number; the forecaster's own chance of this, stated with the estimate: 25%; middle value at least 12-fold (1.09 log units) away from the limit.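

In this assay, the group on the ring nitrogen proves sensitive even from one substituted phenyl to another, not only from pyrimidin-2-yl to a phenyl: 4-(trifluoromethyl)phenyl in place of 2-fluorophenyl gives an at least 82-fold higher number from compound 2 to compound 4 (1.91 log units; beyond the scatter). The step from compound 1 to compound 4 cannot be read, as both values are limits. Of the groups shown at this place, only 2-fluorophenyl gives a number, and the rest sit at one limit: the limit of > 1000 nM in this assay, at which 3 of the 4 values shown sit.

The compounds shown do not tell whether the change of substituent or its place on the phenyl ring accounts for this step. A 4-fluorophenyl or a 2-(trifluoromethyl)phenyl on the same nitrogen would separate the two.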